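The source may hold more compounds than are shown below. What is called first, only, known or untested is meant among the compounds shown, and "the series" means these compounds.

In a functional assay on PC-3 cells (Homo sapiens) for antiproliferative activity, read by MTT assay, with a stated time of 48 h (on this read-out higher numbers stand for weaker inhibition and lower numbers for stronger inhibition), compound 2 `COc1ccc(CN(C(=O)Cn2cc(CSC3=NCCS3)nn2)c2cc(OC)c(OC)c(OC)c2)cc1` gives 16000 nM. Compound 1 `COc1ccc(CN(C(=O)Cn2cc(CSc3nc4ccccc4s3)nn2)c2cc(OC)c(OC)c(OC)c2)cc1` gives 28500 nM, and these two numbers, the only ones available, lie within the usual scatter of each other, so compound 2 stands level with compound 1 and no ranking can be drawn.

Compound 3 `COc1ccc(CN(C(=O)Cn2cc(Cn3ccc4ccccc43)nn2)c2cc(OC)c(OC)c(OC)c2)cc1` keeps the shared core and differs from compound 2 in one place: a group of 9 heavy atoms (8 carbon, 1 nitrogen; one five-membered aromatic ring with 1 hetero atom, one six-membered aromatic ring of carbon only) in place of a group of 6 heavy atoms (3 carbon, 1 nitrogen, 2 sulfur; one five-membered non-aromatic ring with 2 hetero atoms), on a saturated chain carbon bound to an aromatic carbon. The entering group is 1H-indol-1-yl.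

Among the compounds with values here, only one measured step bears on this change: a 1.8-fold lower number from compound 1 to compound 2 (0.25 log units; within the scatter). That step is within the scatter. Compound 1 also carries a five-membered aromatic ring together with a six-membered aromatic ring of carbon only, as 1H-indol-1-yl does, and its 28500 nM stays level with compound 2. Within the data shown here, the resemblance is only partial, and no measured compound shows what happens when the group leaving here, with its sulfur, is replaced. Any step beyond the scatter in this assay is therefore not expected, in either direction, though the uncertainty is wide.

The expected step is a 1.3-fold higher number from compound 2 to compound 3 (0.10 log units; within the scatter). For compound 3 the estimated value is 20000 nM, with an expected range from 6000 nM to 60000 nM.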

Compound 3, half-maximal inhibitory concentration: 2390 nM
Beside the measured number, compound 3's estimate is 8.4-fold (0.92 log units) above it, outside the stated range (below it).
By their numbers in this assay, from the lowest: compound 3; then compounds 2 and 1 (each within the scatter of the next).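

In this assay, the group on the saturated chain carbon bound to an aromatic carbon clearly matters: 1H-indol-1-yl gives a 6.7-fold lower number from compound 2 to compound 3 (0.83 log units; beyond the scatter) and also a 12-fold lower number from compound 1 to compound 3 (1.08 log units; beyond the scatter), both beyond the scatter, whereas the earlier step at this place stayed within it. A five-membered aromatic ring together with a six-membered aromatic ring of carbon only is not enough on its own, since compound 1 carries both and still gives the higher number; the entering group differs from both groups it replaces in holding no sulfur, but two steps cannot show that this is what counts. Nothing measured here explains why the number falls.

The compounds shown leave open whether both rings of 1H-indol-1-yl are needed, which a lone pyrrole ring or a phenyl ring at this place could test. They also leave open how a chlorine or a methoxy group on 1H-indol-1-yl, or a longer chain leading to it, would change the number.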